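Bromo to methyl on the benzyl ring: compound 4

A few compounds are considered here, and "the series" means these few. Any claim that something is new, unique, unknown or untested is made for them only; others in the source may bear on it.

Measured in a functional assay on KYSE-450 cells (Homo sapiens) for inhibition, read by CCK-8 assay, with a stated time of 48 h; a higher number here means a weaker inhibitor, a lower number a stronger inhibitor:
compound 1 `COc1cc(N(Cc2ccc(Br)cc2)C(=O)CSC(=S)N2CCN(C(=O)OC(C)(C)C)CC2)cc(OC)c1OC` gives 10700 nM
compound 3 `COc1ccc(CN(C(=O)CSC(=S)N2CCN(C(=O)OC(C)(C)C)CC2)c2cc(OC)c(OC)c(OC)c2)cc1Br` gives 1850 nM
Compound 2 `COc1cc(N(Cc2ccc(C)cc2)C(=O)CSC(=S)N2CCN(C(=O)OC(C)(C)C)CC2)cc(OC)c1OC` reaches only a limit in this assay, > 20000 nM.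

The cores of compound 1 and compound 3 differ by 3-bromo-4-methoxyphenyl in place of 4-bromophenyl on a saturated chain carbon bound to an amide-type nitrogen, with a 5.8-fold lower number from compound 1 to compound 3 (0.76 log units; beyond the scatter). Compound 4 `COc1ccc(CN(C(=O)CSC(=S)N2CCN(C(=O)OC(C)(C)C)CC2)c2cc(OC)c(OC)c(OC)c2)cc1C` is not yet measured and differs from compound 3 by methyl in place of bromo on an aromatic carbon. The same kind of change, (methyl in place of bromo on an aromatic carbon), gave an at least 1.8-fold higher number from compound 1 to compound 2 (0.27 log units; that floor lies within the scatter); there the group sits para to a large group, whereas in compound 4 it sits ortho to a methoxy group and meta to a large group. On these data alone, the full size of that earlier step is unknown because compound 2 sits at the limit (the limit of > 20000 nM in this assay, at which 1 of the 3 values shown sits). For compound 4 a step of a 3.0-fold higher number from compound 3 to compound 4 (0.47 log units; beyond the scatter) is expected, resting on an at least 1.8-fold higher number from compound 1 to compound 2 (0.27 log units; that floor lies within the scatter). Compound 4 is estimated at 5500 nM, within 2200 nM to 20000 nM.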

Compound 4, half-maximal inhibitory concentration: > 20000 nM
Compound 4 was reported as a limit; the forecaster's own chance of this, stated with the estimate: 12%; middle value at least 3.6-fold (0.56 log units) from the limit.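

In this assay, methyl in place of bromo on the core of compound 3 gives an at least 10-fold higher number from compound 3 to compound 4 (1.03 log units; beyond the scatter), so on this core the bromo group cannot be exchanged for methyl without a large loss. Set beside the earlier step, this does not establish how far the change carries from one core to another: the same change on two cores in this assay, an at least 1.8-fold higher number (0.27 log units; that floor lies within the scatter) from compound 1 to compound 2 and an at least 10-fold higher number (1.03 log units; beyond the scatter) from compound 3 to compound 4; the limit leaves it open whether they differ. The remaining comparison gives an at least 1.8-fold higher number from compound 1 to compound 4 (0.27 log units; that floor lies within the scatter), and the step between compound 2 and compound 4 cannot be read: the limit of > 20000 nM in this assay, at which 2 of the 4 values shown sit.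

Open, on these data alone, is whether chloro or a nitrile in place of the bromo group would hold the value of compound 3 at 1850 nM. Also open, as far as these compounds go, is what the bromo group does on this ring once the methoxy group is replaced by hydrogen.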